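The compounds below may be only part of what the source reports. "The series", "measured", "known", "first", "only" and "open" are said of these compounds alone.

Three related compounds have been measured. In a functional assay on the whole organism (strain NMRI) with Mus musculus as the target, with a stated time of 4 h (a higher number here means that more compound is needed for the effect, a lower number that less compound is needed), compound 3 `Cc1ccc(Cn2cc(CO/N=C/c3c(-c4ccc(C)cc4)nc4ccc(Br)cn34)nn2)cc1` gives 100 mg/kg. Compound 1 `COc1ccc(Cn2cc(CO/N=C/c3c(-c4ccc(C)cc4)nc4ccc(Br)cn34)nn2)cc1` differs from it only by methoxy in place of methyl on an aromatic carbon, and in this assay compound 1 gives 40 mg/kg, a step described as a 2.5-fold lower number from compound 3 to compound 1 (0.40 log units; beyond the scatter). Compound 2 `Cc1ccc(Cn2cc(CO/N=C/c3c(-c4ccc(F)cc4)nc4c(C)cccn34)nn2)cc1` has a core that differs from that of compound 3 in a way not broken down here; in this assay compound 2 gives 40 mg/kg, level with compound 1 at the digits shown.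

Compound 4 `COc1ccc(Cn2cc(CO/N=C/c3c(-c4ccc(F)cc4)nc4c(C)cccn34)nn2)cc1` has not yet been measured. It differs from compound 2 by methoxy in place of methyl on an aromatic carbon, the same change as from compound 3 to compound 1, at the same kind of place. Because that earlier step a 2.5-fold lower number from compound 3 to compound 1 (0.40 log units; beyond the scatter) lay beyond the scatter, a step of similar size is expected here, though resting on one example only. The expected step is a 2.0-fold lower number from compound 2 to compound 4 (0.30 log units; within the scatter). Compound 4 is therefore expected to give about 20 mg/kg, most likely between 10 mg/kg and 40 mg/kg.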

Compound 4, minimum effective dose: 40 mg/kg
The estimate for compound 4 lay 2.0-fold (0.30 log units) below the measured number, and the stated range covers the measured number.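

In this assay, methoxy in place of methyl gives no change at the digits printed from compound 2 to compound 4 (within the scatter), so the lower number seen on the core of compound 3 does not reappear on the core of compound 2. Even so, the two results cannot be told apart: the same change on two cores in this assay, a 2.5-fold lower number (0.40 log units; beyond the scatter) from compound 3 to compound 1 and no change at the digits printed (within the scatter) from compound 2 to compound 4, 2.5-fold (0.40 log units) apart, within the scatter of two such steps. The change can therefore be neither said to carry over between these cores nor said to fail to, and two pairs are too few to show whether the core alters its effect.

From the compounds shown here alone, it remains open how a hydroxyl, an amine or a longer chain such as ethoxy would read at this place. Going by these compounds, it is also open what this change would do on a third core.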